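Trifluoromethyl on the benzyl ring of a CAR agonist scaffold

The source may report more compounds than this note shows. Statements on the series, on what has been measured and on what is new or still open speak of the compounds shown alone.

Measured compounds and their values:
- Compound 1 `C(=N/OCc1ccccc1)\c1c(-c2ccc3ccccc3c2)nc2occn12` gives 840 nM in an assay on HepG2 cells for agonist activity at nuclear receptor subfamily 1 group I member 3 (Homo sapiens), read by a luciferase reporter, with a stated time of 23 h; on this read-out higher numbers stand for an effect only at larger amounts of compound and lower numbers for an effect already at smaller amounts.
- Compound 2 `Clc1ccc(CO/N=C/c2c(-c3ccc(-c4ccccc4)cc3)nc3sccn23)cc1Cl` is reported as "not active" (no number reported) in this assay.
- Compound 3 `Clc1ccc(CO/N=C/c2c(-c3ccc4ccccc4c3)nc3sccn23)cc1Cl` gives 380 nM in this assay.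

Among the two compounds with a number, compound 1 stands highest. Compound 3 carries a different core and a different benzyl substitution, so the two values can only be set side by side: the number of compound 3 is the lower of the two, by a margin beyond the usual scatter. Compound 2, with a biphenyl in place of the naphthyl, gave no measurable effect.

Compound 4 `FC(F)(F)c1ccc(CO/N=C/c2c(-c3ccc4ccccc4c3)nc3occn23)cc1` differs from compound 1 in one place: trifluoromethyl in place of hydrogen on an aromatic carbon. The shared core and the naphthyl group remain as in compound 1. Going by the values given here, no measured pair shows this particular change, so the expectation rests on compound 1 alone and on the lower value of compound 3. The step of a 1.7-fold lower number from compound 1 to compound 4 (0.23 log units; within the scatter) is expected to be small and directed toward lower numbers, close to the edge of the scatter. Compound 4 is accordingly estimated at 500 nM, with a range from 150 nM to 1600 nM.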

Compound 4, half-maximal effective concentration: 470 nM
The estimate for compound 4 lay 1.1-fold (0.03 log units) above the measured number, within the range that was stated.
By their numbers in this assay, from the lowest: compounds 3, 4 and 1 (each within the scatter of the next, the first and the last beyond it).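

Going by these compounds alone, the first single-place change puts trifluoromethyl on an aromatic carbon of the six-membered ring, para to a large group, and in this assay it gives a 1.8-fold lower number from compound 1 to compound 4 (0.25 log units; within the scatter). This shows that the position accepts a group of four heavy atoms in place of hydrogen while a measurable number is kept, and the step cannot be told apart from repeated measurement of the same compound. Nothing measured here offers an explanation for this result.

The compounds shown leave open whether a carboxylic acid, an amine or a longer alkyl chain at this same place would also keep a number in this range. They also leave open whether the phenyl to 4-(trifluoromethyl)phenyl change would give a similar step on another core or with another aryl group.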